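Chloro on the core of compound 1: expected effect in cytotoxicity assay

The source may report more compounds than this note shows. Statements on the series, on what has been measured and on what is new or still open speak of the compounds shown alone.

Measured compounds:
compound 1 `COc1ccc(-c2cc(-c3cc4ccccc4n3C)no2)cc1` gives > 100000 nM in a functional assay on Calu-3 cells (Homo sapiens) for cytotoxicity, read by WST assay, with a stated time of 72 h (a lower number here means a stronger inhibitor, a higher number a weaker inhibitor), a limit of the assay.
compound 2 `COc1ccc(-c2cc(-c3cc4ccccc4[nH]3)no2)cc1` gives > 100000 nM in this assay, a limit of the assay.

Compound 1 stands only at a limit in this assay, not at a number. Within the data shown here, the one measured change, a step that the two limits leave unreadable from compound 1 to compound 2, is hydrogen in place of methyl on an aromatic nitrogen, and its size cannot be read because of the limit of > 100000 nM in this assay, at which 2 of the 2 values shown sit. Nothing in the measured pair therefore gives a direction or a size for any further change.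

Compound 3 `COc1ccc(-c2cc(-c3c(Cl)c4ccccc4n3C)no2)cc1` differs from compound 1 by chloro in place of hydrogen on an aromatic carbon. Among the measured compounds shown here, no measured step bears on a chloro entering at this place, so no size of step beyond the scatter can be drawn from the data. The only anchor is that compound 1 sits at the limit, and the series so far has shown no compound with a readable number.

Compound 3 is expected to give 120000 nM in this assay, within 20000 nM to 500000 nM, and a limit rather than a number is the likelier report. The step this estimate implies, a step that the limit leaves unreadable from compound 1 to compound 3, is an expectation only.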

Compound 3, half-maximal inhibitory concentration: 60900 nM
For compound 3 the middle estimate is 2.0-fold (0.29 log units) above the measured one; low and high end bracket the measured number.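

Chloro in place of hydrogen on an aromatic carbon of the five-membered aromatic ring gives, in this assay, an at least 1.6-fold lower number from compound 1 to compound 3 (0.21 log units; that floor lies within the scatter). Among these compounds, this is the first change with a readable direction, and the place, next to the ring atom that bears a large group, now has a number attached to it; but the step starts from a limit, so only its floor is known, and that floor does not clear the scatter. The earlier change, hydrogen in place of methyl on an aromatic nitrogen, still cannot be read, and compound 3 alone stands at a number: the limit of > 100000 nM in this assay, at which 2 of the 3 values shown sit.

Whether the lower number belongs to chloro in particular stays open, since no other group at this place, such as bromo, methyl, an amine or a carboxylic acid, appears among the compounds shown. Also open, going by these compounds, is whether chloro at this place would give a number when hydrogen rather than methyl sits on the ring nitrogen, as in compound 2, and how far the true step from the limit of compound 1 runs.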